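Taking the 2-carboxyphenyl group off compound 3

The source may report more compounds than this note shows. Statements on the series, on what has been measured and on what is new or still open speak of the compounds shown alone.

Compound 1 `O=C(O)CCC(=O)N1C/C(=C\c2ccccc2F)C(=O)/C(=C/c2ccccc2F)C1` gives 69000 nM
Compound 2 `O=C(O)CCCC(=O)N1C/C(=C\c2ccccc2F)C(=O)/C(=C/c2ccccc2F)C1` gives 60000 nM
Compound 3 `O=C1/C(=C/c2ccccc2F)CN(C(=O)c2ccccc2C(=O)O)C/C1=C\c1ccccc1F` gives 56000 nM

These values come from a functional assay on NCI-H441 cells (Homo sapiens) for antiproliferative activity, with a stated time of 24 h (a lower number here means a stronger inhibitor, a higher number a weaker inhibitor), and all three compounds carry a carboxy group. Compound 3 stands level with the other two, as the measured steps show: a 1.2-fold lower number from compound 1 to compound 3 (0.09 log units; within the scatter) and a 1.1-fold lower number from compound 2 to compound 3 (0.03 log units; within the scatter) in this assay with no separation beyond the scatter. The remaining measured step is a 1.2-fold lower number from compound 1 to compound 2 (0.06 log units; within the scatter) and it tells the same story.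

Compound 4 `O=CN1C/C(=C\c2ccccc2F)C(=O)/C(=C/c2ccccc2F)C1` has hydrogen in place of 2-carboxyphenyl on a carbonyl carbon and so has no carboxy group. Each measured step swapped one carboxy-bearing group for another, and none removed the carboxy group. They therefore offer only a weak guide to this change. A modest move to a lower number in this assay is expected, though the reverse cannot be ruled out. The expected step is a 1.6-fold lower number from compound 3 to compound 4 (0.20 log units; within the scatter) and this is only a loose estimate. For compound 4 the estimated value is 35000 nM (expected range 10000 nM to 80000 nM) for now.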

Compound 4, half-maximal inhibitory concentration: 49000 nM
For compound 4 the middle estimate is 1.4-fold (0.15 log units) below the measured one, within the range that was stated.
By their numbers in this assay, from the lowest: compounds 4, 3, 2 and 1 (each within the scatter of the next).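

Compound 4 keeps only hydrogen on the carbonyl carbon, and in this assay this loss of the whole carboxy-bearing group gives a 1.1-fold lower number from compound 3 to compound 4 (0.06 log units; within the scatter), a 1.2-fold lower number from compound 2 to compound 4 (0.09 log units; within the scatter) and a 1.4-fold lower number from compound 1 to compound 4 (0.15 log units; within the scatter). The earlier steps only swapped one carboxy-bearing group for another, whereas these show that, among these four compounds, a carboxy group at this place is not needed to reach the numbers seen, and that removing one leaves compound 4 level with the others. Nothing measured here offers an explanation for this flat result.

Going by these compounds, what remains open is whether any group at this place can separate from these four compounds at all. A chain ending in an amine, a plain phenyl or a longer carbon chain without a carboxylic acid could test that.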